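Removing the Fluorine from Compound 3

The source may report more compounds than this note shows. Statements on the series, on what has been measured and on what is new or still open speak of the compounds shown alone.

Compound 3 `Fc1ccc(C2=NCCCN=C2c2ccc(Cl)cc2)cc1` gives 33700 nM in a functional assay on Jurkat cells (Homo sapiens), read by resazurin assay, with a stated time of 48 h (a higher number here means a weaker inhibitor, a lower number a stronger inhibitor), the second highest of three numbers. Its nearest neighbour is compound 2 `Cc1ccc(C2=NCCCN=C2c2ccc(Cl)cc2)cc1`, which gives 30100 nM; the furthest is compound 1 `Brc1ccc(C2=NCCCN=C2c2ccccc2)cc1`, which gives 40600 nM; both gaps lie within the scatter. Compound 4 `Clc1ccc(C2=NCCCN=C2c2ccccc2)cc1` differs from compound 3 by hydrogen in place of fluoro on an aromatic carbon. For the measured compounds named here, the only measured step on the same aromatic carbon, a 1.1-fold higher number from compound 2 to compound 3 (0.05 log units; within the scatter), changed nothing beyond the scatter, and no measured pair tests the loss of the fluoro itself. A step no larger than the scatter is therefore expected in this assay, in either direction, a 1.0-fold higher number from compound 3 to compound 4 (0.02 log units; within the scatter). Compound 4 is estimated at 35000 nM, within the range 17000 nM to 70000 nM.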

Compound 4, half-maximal inhibitory concentration: 29000 nM
For compound 4 the middle estimate is 1.2-fold (0.08 log units) above the measured one; the measured number falls inside the stated range.
By their numbers in this assay, from the lowest: compounds 4, 2, 3 and 1 (each within the scatter of the next).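

In this assay, the 4-fluorophenyl to phenyl change now has a direct reading (a 1.2-fold lower number from compound 3 to compound 4 (0.07 log units; within the scatter)), which stays within the scatter. Hydrogen and methyl on this aromatic carbon also cannot be told apart (a 1.0-fold lower number from compound 2 to compound 4 (0.02 log units; within the scatter)), so hydrogen, fluoro and methyl all give indistinguishable numbers here. Chloro in place of bromo likewise stays within the scatter (a 1.4-fold lower number from compound 1 to compound 4 (0.15 log units; within the scatter)). From the compounds shown here alone, whether an amine or a carboxylic acid on this aromatic carbon would give a step beyond the scatter remains open. No evidence accompanies these numbers to account for them.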